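Biaryl hydroxyl variation on the cyclopentane ether series

The compounds below may be only part of what the source reports. "The series", "measured", "known", "first", "only" and "open" are said of these compounds alone.

Measured compounds:
Compound 1 `O=C(O)CC/C=C\CO[C@H]1C(OCc2ccc(-c3ccccc3CCO)cc2)CC[C@@H]1N1CCCCCC1`: 31.6 nM
Compound 2 `O=C(O)CC/C=C\CO[C@H]1C(OCc2ccc(-c3ccc(CO)cc3)cc2)CC[C@@H]1N1CCCCCC1`: 20 nM

In a functional assay for antagonist activity at thromboxane A2 receptor (Rattus norvegicus) (a higher number here means weaker binding, a lower number tighter binding), compound 2 gives 20 nM, the lowest of the two numbers; the nearest is compound 1 at 31.6 nM, and the step of a 1.6-fold lower number from compound 1 to compound 2 (0.20 log units; within the scatter) is within the scatter, so the two cannot be ordered.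

Compound 3 `O=C(O)CC/C=C\CO[C@H]1C(OCc2ccc(-c3ccccc3O)cc2)CC[C@@H]1N1CCCCCC1` is not yet measured. It differs from compound 2 in one place: 2-hydroxyphenyl in place of 4-(hydroxymethyl)phenyl on an aromatic carbon.

Within the data shown here, the only step that bears on this change is the one across the same biaryl substituent, a 1.6-fold lower number from compound 1 to compound 2 (0.20 log units; within the scatter), which stayed within the scatter when the hydroxyl-bearing group on that ring was moved and shortened. Among the measured compounds shown here, no other step touches this region. The step to compound 3 is therefore expected to lie within the scatter as well, with no clear direction.

For compound 3 in this assay the estimate is 25 nM, range 8 nM to 80 nM, a step of a 1.3-fold higher number from compound 2 to compound 3 (0.10 log units; within the scatter) from compound 2.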

Compound 3, dissociation constant: 20 nM
Estimate against measurement, compound 3: 1.3-fold (0.10 log units) above; measured number inside the range.
By their numbers in this assay, from the lowest: compounds 2, 3 and 1 (each within the scatter of the next).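

In this assay, 2-hydroxyphenyl in place of 4-(hydroxymethyl)phenyl gives no change at the digits printed from compound 2 to compound 3 (within the scatter) and hydroxy in place of 2-hydroxyethyl gives a 1.6-fold lower number from compound 1 to compound 3 (0.20 log units; within the scatter) on the same biaryl substituent. The earlier pair showed only that a hydroxyl carried on a chain could differ in chain and ring placement without a readable shift; compound 3 extends this to a hydroxyl set directly on the ring, so compounds 1, 2 and 3 cannot be ordered at this position. No supporting data are available to account for this flat response.

The compounds shown all carry a hydroxyl on this ring, so they leave open whether the hydroxyl matters at all, which an unsubstituted phenyl would test. They also leave open whether an aminomethyl group or a carboxylic acid at this position would stay within the scatter or produce a readable step.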